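Alpha-ketooxazole series: deprotection of compound 2

The source may report more compounds than this note shows. Statements on the series, on what has been measured and on what is new or still open speak of the compounds shown alone.

Measured so far:
compound 1, `O=C(CCCCCCc1ccccc1)c1ncc(-c2ccc(CO)cn2)o1`, an assay for inhibition of Fatty-acid amide hydrolase 1 (Rattus norvegicus), using a Dixon plot (on this read-out higher numbers stand for weaker inhibition and lower numbers for stronger inhibition), 3.2 nM
compound 2, `COCOCCCCCc1cnc(C(=O)CCCCCCc2ccccc2)o1`, this assay 24.1 nM

Compound 2 gives the highest number of the two measured in this assay; the nearest is compound 1, and the step of a 7.5-fold higher number from compound 1 to compound 2 (0.88 log units; beyond the scatter) puts the two apart beyond the scatter. Compound 3, `O=C(CCCCCCc1ccccc1)c1ncc(CCCCCO)o1`, has not yet been measured. It differs from compound 2 by hydrogen in place of methoxymethyl on an oxygen on a saturated carbon, in words: hydrogen in place of methoxymethyl on an oxygen on a saturated carbon.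

Going by the values given here, no measured step matches this change directly. Among the compounds with values here, the only measured step, a 7.5-fold higher number from compound 1 to compound 2 (0.88 log units; beyond the scatter), swaps a hydroxymethyl-bearing aromatic ring for the methoxymethyl-capped chain, so it bears on the present step only loosely: it shows that the measured compound carrying a free hydroxyl, compound 1, sits at the lower number. On that ground a modest move toward lower numbers is expected for compound 3, a 2.4-fold lower number from compound 2 to compound 3 (0.38 log units; beyond the scatter), though the chain and the ring differ in more than the cap, so the expectation is held with a wide range. Compound 3 is estimated at 10 nM, between 3 nM and 40 nM.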

Compound 3, inhibition constant: 10.1 nM
Beside the measured number, compound 3's estimate is 1.0-fold (0.00 log units) below it; the measured number falls inside the stated range.
By their numbers in this assay, from the lowest: compound 1; then compound 3; then compound 2.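

In this assay, going by these compounds alone, the step of a 2.4-fold lower number from compound 2 to compound 3 (0.38 log units; beyond the scatter) is the first to isolate the cap on the oxygen: hydrogen in place of methoxymethyl, on an oxygen on a saturated carbon, with the rest of the structure unchanged, and the step lies beyond the scatter. The free hydroxy on the chain does not by itself close the gap to the ring-bearing compound, since 5-hydroxypentyl in place of 5-(hydroxymethyl)pyridin-2-yl on the aromatic carbon still gives a 3.2-fold higher number from compound 1 to compound 3 (0.50 log units; beyond the scatter) and this step also lies beyond the scatter. The cap on the chain and the group on the aromatic carbon therefore both register in this read-out, but no supporting data are available to explain either step.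

The compounds shown leave open whether the lower number of compound 3 depends on the hydroxy hydrogen itself or on the absence of the larger cap, a question that a methyl ether on the same chain would address. Also open, on these data alone, is how the chain end tolerates a carboxylic acid or an amine in place of the hydroxy, and how a longer chain carrying the same hydroxy compares.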